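Chloro to Bromo in a Small Amide Series

The source may report more compounds than this note shows. Statements on the series, on what has been measured and on what is new or still open speak of the compounds shown alone.

Compound 3 `COc1cc2ncnc(Nc3ccc(NC(=O)c4ccc(Cl)cc4)cc3)c2cc1OC` gives 28000 nM in a functional assay on HepG2 cells (Homo sapiens) for inhibition, read by MTT assay (on this read-out higher numbers stand for weaker inhibition and lower numbers for stronger inhibition), and shares its level with one neighbour. Compound 1 `COc1cc2ncnc(Nc3ccc(NC(=O)c4ccccc4C)cc3)c2cc1OC` gives 15000 nM there, and the gap a 1.9-fold higher number from compound 1 to compound 3 (0.27 log units; within the scatter) is no real difference. Compound 2 `COc1cc2ncnc(Nc3ccc(NC(=O)c4ccc(C(C)(C)C)cc4)cc3)c2cc1OC` shows > 100000 nM as a limit of the assay, not a number. For the measured compounds named here, the one measured step that changes only the group on this carbon is an at least 3.5-fold lower number from compound 2 to compound 3 (0.55 log units; beyond the scatter) and it involves tert-butyl, while no measured step swaps one halogen for another. Going by the values given here, compound 4 `COc1cc2ncnc(Nc3ccc(NC(=O)c4ccc(Br)cc4)cc3)c2cc1OC` carries bromo in place of chloro on an aromatic carbon as its only change, bromo in place of chloro on an aromatic carbon. No shift beyond the scatter is expected, so the estimated move is a 1.1-fold lower number from compound 3 to compound 4 (0.03 log units; within the scatter) at most a small one. For compound 4 the expected value is 26000 nM with an estimated range of 12000 nM to 60000 nM as the likely span.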

Compound 4, half-maximal inhibitory concentration: 35000 nM
For compound 4 the middle estimate is 1.3-fold (0.13 log units) below the measured one; low and high end bracket the measured number.
By their numbers in this assay, from the lowest: compounds 1, 3 and 4 (each within the scatter of the next, the first and the last beyond it). At a limit, above all of these: compound 2.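

In this assay, bromo in place of chloro on this aromatic carbon gives a 1.3-fold higher number from compound 3 to compound 4 (0.10 log units; within the scatter) and leaves the two halogens indistinguishable here. Bromo keeps the separation from tert-butyl that chloro showed, with an at least 2.8-fold lower number from compound 2 to compound 4 (0.45 log units; beyond the scatter) as the step, although compound 2 gives only a limit of the assay, not a number: the limit of > 100000 nM in this assay, at which 1 of the 4 values shown sits. Unlike the chloro step from the same starting point, the bromo step clears the scatter, with a 2.3-fold higher number from compound 1 to compound 4 (0.37 log units; beyond the scatter) as a modest move.

From the compounds shown here alone, what an amine or a carboxylic acid would give at this position remains open.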